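Aryl Heterocycle Exchange on an Imidazoline Alpha-1D Series

The compounds below may be only part of what the source reports. "The series", "measured", "known", "first", "only" and "open" are said of these compounds alone.

Compound 1 `c1cncc(-c2ccccc2OCC2=NCCN2)c1`: 158 nM
Compound 2 `c1ccc(-c2ccsc2)c(OCC2=NCCN2)c1`: 12.6 nM
Compound 3 `c1ccc(-c2cc[nH]n2)c(OCC2=NCCN2)c1`: < 100000 nM

Of the compounds shown here, three sharing one core have been tested in a functional assay for activation of Alpha-1D adrenergic receptor (Homo sapiens), read by calcium flux; a higher number here means that more compound is needed for the effect, a lower number that less compound is needed. Compound 1 gives 158 nM. Compound 2 gives 12.6 nM, and the change a 13-fold lower number from compound 1 to compound 2 (1.10 log units; beyond the scatter) shows how much the five-membered sulfur ring is favoured over the pyridine here. For compound 3 the assay reports only a limit, < 100000 nM; this is one of the values that sit at the limit of < 100000 nM in this assay, at which 1 of the 3 values shown sits, so compound 3 cannot be placed against the other two, and the steps a step that the limit leaves unreadable from compound 1 to compound 3 and a step that the limit leaves unreadable from compound 2 to compound 3 stay unreadable.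

Compound 4 `Cc1cnsc1-c1ccccc1OCC1=NCCN1` has not yet been measured. It differs from compound 3 in one place: 4-methyl-1,2-thiazol-5-yl in place of 1H-pyrazol-3-yl on an aromatic carbon. Within the data shown here, of the measured steps, only the one from compound 1 to compound 2 gives a readable size, and it points the same way, from a nitrogen-bearing ring toward a sulfur-bearing one. Neither step into compound 3 can be sized, so the step that the limit leaves unreadable from compound 3 to compound 4 is expected in direction only, toward a lower number. Compound 4 is therefore expected to give about 60 nM in this assay, within a range of 10 nM to 400 nM.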

Compound 4, half-maximal effective concentration: < 100000 nM
Compound 4: only a limit was reported; the forecaster's own chance of this, stated with the estimate: 10%; the middle value lies beyond the limit too.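

In this assay compound 4 is reported only as a limit, < 100000 nM, so no step from compound 1, compound 2 or compound 3 to compound 4 can be read: the limit of < 100000 nM in this assay, at which 2 of the 4 values shown sit.

The compounds shown leave open what separates the 4-methyl-1,2-thiazol-5-yl and 1H-pyrazol-3-yl compounds from the measurable thiophen-3-yl and pyridin-3-yl compounds in this assay.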